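Benzyloxy versus phenylcarbamoyl at the saturated ring carbon

A few compounds are considered here, and "the series" means these few. Any claim that something is new, unique, unknown or untested is made for them only; others in the source may bear on it.

Measured compounds:
compound 1 `Cc1nn(-c2ncnc3nc[nH]c23)c2c1C(OCc1ccc(Cl)cc1Cl)CC(=O)N2` 4 nM
compound 2 `Cc1nn(-c2ncnc3nc[nH]c23)c2c1C(C(=O)Nc1ccccc1)CC(=O)N2` 10 nM
compound 3 `Cc1nn(-c2ncnc3nc[nH]c23)c2c1C(OCc1ccc(F)cc1)CC(=O)N2` 1 nM

In a functional assay on HEK293 cells for agonist activity at G-protein coupled receptor 39 (Homo sapiens), read by scintillation proximity assay and inositol phosphate accumulation, with a stated time of 75 min, in the presence of a further agent that is not named here (on this read-out lower numbers stand for an effect already at smaller amounts and higher numbers for an effect only at larger amounts of compound), compound 2 gives the highest of the three numbers. The step of a 2.5-fold higher number from compound 1 to compound 2 (0.40 log units; beyond the scatter) and the step of a 10-fold lower number from compound 2 to compound 3 (1.00 log units; beyond the scatter) both run beyond the scatter, and within the benzyloxy pair the step of a 4.0-fold lower number from compound 1 to compound 3 (0.60 log units; beyond the scatter) also does. Compound 4 `Cc1nn(-c2ncnc3nc[nH]c23)c2c1C(OCc1ccccc1Cl)CC(=O)N2` differs from compound 2 in one place: (2-chlorobenzyl)oxy in place of phenylcarbamoyl on a saturated ring carbon. The two measured steps from phenylcarbamoyl to a benzyloxy group both gave lower numbers, so a lower number is expected for compound 4 as well, in a size between those two, namely a 3.3-fold lower number from compound 2 to compound 4 (0.52 log units; beyond the scatter). Compound 4 is therefore estimated at 3 nM, with a range from 1 nM to 10 nM.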

Compound 4, half-maximal effective concentration: 2 nM
Estimate against measurement, compound 4: 1.5-fold (0.18 log units) above, within the range that was stated.
By their numbers in this assay, from the lowest: compounds 3, 4 and 1 (each within the scatter of the next, the first and the last beyond it); then compound 2.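

The (2-chlorobenzyl)oxy group also gives a lower number than phenylcarbamoyl on this saturated ring carbon (a 5.0-fold lower number from compound 2 to compound 4 (0.70 log units; beyond the scatter)), so all three benzyloxy compounds now stand below compound 2. Among the benzyloxy compounds, the new member cannot be separated from the other two (a 2.0-fold higher number from compound 3 to compound 4 (0.30 log units; within the scatter); a 2.0-fold lower number from compound 1 to compound 4 (0.30 log units; within the scatter)). Hydrogen in place of chloro on the aromatic carbon therefore brings no readable change.

No measurement is available that would explain these steps. Still open, on these data alone, is how an amine or carboxylic acid on the benzyl ring, or a longer chain in place of the benzyloxy group, would fare at this position.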